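Metabolic stability notes: naphthyl-to-methylpyridyl change at the amine

This account rests on a few compounds, and the source may have more. Where it says the series, first, only, none or still open, it means among the compounds named here.

The series shares one core; compound 1 is `CC(C)(C)CCC1(NCc2ccc3ccccc3c2)C(=O)C(C2=NS(=O)(=O)c3cc(NS(C)(=O)=O)ccc3N2)=C(O)c2ccccc21`, compound 2 is `Cc1cccc(C)c1CN[C@]1(CCC(C)(C)C)C(=O)C(C2=NS(=O)(=O)c3cc(NS(C)(=O)=O)ccc3N2)=C(O)c2ccccc21` and compound 3 is `CC(C)CC[C@@]1(NS(C)(=O)=O)C(=O)C(C2=NS(=O)(=O)c3cc(NS(C)(=O)=O)ccc3N2)=C(O)c2ccccc21`. In an in vivo ADME assay on the whole organism (strain Sprague-Dawley) for metabolic stability, with Rattus norvegicus as the target, at a dose of 5 mg/kg by the intravenous route (a higher number here means that the compound lasts longer, a lower number that the compound disappears faster), compound 1 gives 2.2 h, the second highest of the three numbers. Compound 2 gives 3.1 h, which lies within the scatter of compound 1. Compound 3 gives 0.2 h, beyond the scatter and far lower than compound 1. Compound 4, `Cc1cccc(CNC2(CCC(C)(C)C)C(=O)C(C3=NS(=O)(=O)c4cc(NS(C)(=O)=O)ccc4N3)=C(O)c3ccccc32)n1`, is still to be measured in this assay. It differs from compound 1 by 6-methylpyridin-2-yl in place of naphthalen-2-yl on a saturated chain carbon bound to an amine nitrogen. For the measured compounds named here, no comparable pair among the measured compounds is known, so the step from compound 1 to compound 4 is expected to stay within the scatter, with a 1.2-fold lower number from compound 1 to compound 4 (0.09 log units; within the scatter) as the estimated step. Compound 4 is therefore estimated at 1.8 h, with a range from 0.8 h to 4 h.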

Compound 4, half-life: 1 h
The estimate for compound 4 lay 1.8-fold (0.26 log units) above the measured number; low and high end bracket the measured number.
By their numbers in this assay, from the lowest: compound 3; then compound 4; then compounds 1 and 2 (each within the scatter of the next).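

In this assay, 6-methylpyridin-2-yl in place of naphthalen-2-yl on a saturated chain carbon bound to an amine nitrogen gives a 2.2-fold lower number from compound 1 to compound 4 (0.34 log units; beyond the scatter). This first single-place comparison in the series shows that the half-life responds to the aromatic group at this position, though the step is modest. No measured property bears on the reason for the step.

Still open, on these data alone, is whether the ring nitrogen, the methyl or the loss of the second aromatic ring accounts for the step. Plain phenyl and unsubstituted pyridin-2-yl at this position would help separate these.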